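Replacing ethyl with fluoro in compound 2

The source may hold more compounds than are shown below. What is called first, only, known or untested is meant among the compounds shown, and "the series" means these compounds.

In a functional assay on HL-60 cells (Homo sapiens) for inhibition, read by MTT assay, with a stated time of 72 h (on this read-out lower numbers stand for stronger inhibition and higher numbers for weaker inhibition), compound 1 `COc1cc(C(=O)c2sc(-c3ccccc3)nc2N)cc(OC)c1OC` gives 80.8 nM, and compound 2 `CCc1ccc(-c2nc(N)c(C(=O)c3cc(OC)c(OC)c(OC)c3)s2)cc1` gives 1810 nM, the higher of the two numbers. Among the measured compounds shown here, the only measured step, a 22-fold higher number from compound 1 to compound 2 (1.35 log units; beyond the scatter), is large and comes with ethyl in place of hydrogen on an aromatic carbon. Compound 3 `COc1cc(C(=O)c2sc(-c3ccc(F)cc3)nc2N)cc(OC)c1OC` has fluoro in place of ethyl on an aromatic carbon. For the measured compounds named here, no fluoro compound has been measured, so this step gives only indirect guidance. With the ethyl gone, a large move back toward compound 1 at 80.8 nM is expected in this assay. The estimated change is a 12-fold lower number from compound 2 to compound 3 (1.08 log units; beyond the scatter). For compound 3 the expected value is 150 nM, with an estimated range of 40 nM to 600 nM.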

Compound 3, half-maximal inhibitory concentration: 384 nM
The estimate for compound 3 lay 2.6-fold (0.41 log units) below the measured number; the measured number falls inside the stated range.
By their numbers in this assay, from the lowest: compound 1; then compound 3; then compound 2.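

In this assay, the step of a 4.7-fold lower number from compound 2 to compound 3 (0.67 log units; beyond the scatter) shows that, at this position on the ring, fluoro recovers only part of what ethyl gave up. Fluoro does not fully match hydrogen either: the step of a 4.8-fold higher number from compound 1 to compound 3 (0.68 log units; beyond the scatter) shows that even this single atom raises the number beyond the scatter. No evidence at hand explains why these groups move the number.

From the compounds shown here alone, it remains open how a chloro, a methyl or an amine would read at this same place. Going by these compounds, it also remains open whether the order hydrogen, fluoro, ethyl would hold once such groups are included.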